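A Chain Swap Tried on a Weakly Active Compound

The compounds below may be only part of what the source reports. "The series", "measured", "known", "first", "only" and "open" are said of these compounds alone.

So far, three compounds have been tested in a functional assay on HCT-116 cells (Homo sapiens) for antiproliferative activity, read by CCK-8 assay, with a stated time of 72 h, tested at 2 uM; on this read-out lower numbers stand for a weaker effect and higher numbers for a stronger effect at the one concentration tested. Compound 3 `CC(C)n1cnc2c(NCc3ccc(C(=O)Nc4ccccc4N)cc3)nc(Cl)nc21` gives 73.2% in this assay. Compound 2 `CCCCn1cnc2c(NCc3ccc(C(=O)Nc4ccccc4N)cc3)nc(Cl)nc21` carries butyl in place of isopropyl on an aromatic nitrogen; in this assay compound 2 gives 4.89%, and the change produced a number 68.3 percentage points lower from compound 3 to compound 2 (beyond the scatter). Compound 1 `CC(C)n1cnc2c(Nc3ccccc3)nc(NCOCc3ccc(/C=C/C(=O)Nc4ccccc4N)cc3)nc21` is built on a different core, and the difference between the two cores is not broken down here. In this assay, among the compounds with values here, compound 1 gives 2.53%, a number that lies within the usual scatter of the one found for compound 2.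

Compound 4 `CCCCn1cnc2c(Nc3ccccc3)nc(NCOCc3ccc(/C=C/C(=O)Nc4ccccc4N)cc3)nc21` has not yet been measured. It differs from compound 1 by butyl in place of isopropyl on an aromatic nitrogen, the same change that separates compound 3 from compound 2, made at the same place. Within the data shown here, that change is known from only one pair, where it lowered the read-out by a large amount. Compound 1, however, already sits close to the bottom of the scale because 2.53% leaves almost no room for a further fall, so a much smaller step is expected here. From compound 1 to compound 4 the expected step is a number 0.5 percentage points higher from compound 1 to compound 4 (within the scatter). For compound 4 in this assay the expected value is 3%, with a likely range from 0% to 12%.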

Compound 4, a percentage reported as inhibition, at one concentration (the size of the read-out at that concentration, not a potency): 6.58%
Estimate against measurement, compound 4: 3.6 percentage points below; measured number inside the range.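

In this assay, the swap of isopropyl for butyl on the aromatic nitrogen gives a number 4.1 percentage points higher from compound 1 to compound 4 (within the scatter), so on the core of compound 1 the change has no effect that can be told apart from the usual scatter. The same swap therefore does not carry over from one core to the other with the same size, and a large loss seen on one core cannot simply be assumed on another: the same change on two cores in this assay, a number 68.3 percentage points lower (beyond the scatter) from compound 3 to compound 2 and a number 4.1 percentage points higher (within the scatter) from compound 1 to compound 4, 72.4 percentage points apart, beyond the scatter of two such steps This does not show that the core of compound 1 tolerates butyl any better, since compound 1 starts at only 2.53% and has almost no room to fall, whereas compound 3 starts at 73.2%, and two pairs cannot explain why the steps differ.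

The compounds shown leave open how the read-out responds to other groups on that nitrogen, such as an ethyl group, a propyl chain, a longer hexyl chain or a cyclopentyl ring, on either core. They also leave open whether the swap would have a clearer effect on a compound of the core of compound 1 that starts higher on the scale.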